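The compounds below may be only part of what the source reports. "The series", "measured", "known", "first", "only" and "open" are said of these compounds alone.

Going by the values given here, compound 1 `COCC(=O)N(Cc1ccc(OC)c(O)c1)c1cc(OC)c(OC)c(OC)c1` gives the lowest number of the two so far in a functional assay on MGC-803 cells (Homo sapiens) for inhibition, read by MTT assay, with a stated time of 48 h (a higher number here means a weaker inhibitor, a lower number a stronger inhibitor), namely 79 nM, while compound 2 `COc1ccc(N(Cc2cc(OC)c(OC)c(OC)c2)C(=O)CCl)cc1O` stands far apart from it in this assay with 24500 nM. Compound 3 `CCC(=O)N(Cc1ccc(OC)c(O)c1)c1cc(OC)c(OC)c(OC)c1` differs from compound 1 only by methyl in place of methoxy on a saturated chain carbon bound to a carbonyl carbon. Among the compounds with values here, no measured pair isolates this change, so the step is expected to be small, if anything a slight loss, and within the scatter in this assay. The step from compound 1 to compound 3 is therefore estimated at a 1.5-fold higher number from compound 1 to compound 3 (0.18 log units; within the scatter). Compound 3 is expected to reach 120 nM in this assay, between 40 nM and 400 nM.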

Compound 3, half-maximal inhibitory concentration: 50 nM
Beside the measured number, compound 3's estimate is 2.4-fold (0.38 log units) above it; measured number inside the range.
By their numbers in this assay, from the lowest: compounds 3 and 1 (each within the scatter of the next); then compound 2.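

In this assay, methyl in place of methoxy on a saturated chain carbon bound to a carbonyl carbon gives a 1.6-fold lower number from compound 1 to compound 3 (0.20 log units; within the scatter) and so leaves the number in the same range. At this position, then, the methoxy group is not required for a value of this order, and methoxymethyl and ethyl cannot be told apart here. Nothing available explains why the two groups read alike.

As far as these compounds go, whether a longer chain, a hydroxyl group or an amine on this carbon would hold the number in this range remains open.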